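Extending the aryl ether chain: from compound 2 to compound 4

A few compounds are considered here, and "the series" means these few. Any claim that something is new, unique, unknown or untested is made for them only; others in the source may bear on it.

Compound 1 `O=C1CC(c2ccccc2O)Oc2ccccc21` gives 71300 nM in a functional assay on J774.A1 cells (Mus musculus) for inhibition, read by Griess assay, with stated times of 1 h and 24 h; on this read-out lower numbers stand for stronger inhibition and higher numbers for weaker inhibition. Compound 2 `COCOc1ccccc1C1CC(=O)c2ccccc2O1` gives 35200 nM, and compound 3 `CCOc1ccccc1C1CC(=O)c2ccccc2O1` gives 38800 nM. Compound 2 holds the lowest of the three numbers, though only its gap to compound 1 is beyond the scatter: a 2.0-fold lower number from compound 1 to compound 2 (0.31 log units; beyond the scatter), whereas a 1.8-fold lower number from compound 1 to compound 3 (0.26 log units; within the scatter) and a 1.1-fold higher number from compound 2 to compound 3 (0.04 log units; within the scatter). The next step goes to compound 4 `CCCCOc1ccccc1C1CC(=O)c2ccccc2O1`, where (propyl in place of methoxy on a saturated chain carbon bound to an oxygen on an aromatic ring). The step that bears most directly is the one already measured at that same saturated chain carbon, which stayed within the scatter; the chain extension here is of the same kind. Little movement is therefore expected, a 1.0-fold higher number from compound 2 to compound 4 (0.01 log units; within the scatter), with no direction beyond the scatter. Compound 4 is estimated at 36000 nM, in a range from 16000 nM to 80000 nM.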

Compound 4, half-maximal inhibitory concentration: 47700 nM
Beside the measured number, compound 4's estimate is 1.3-fold (0.12 log units) below it, within the range that was stated.
By their numbers in this assay, from the lowest: compounds 2, 3, 4 and 1 (each within the scatter of the next, the first and the last beyond it).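

In this assay the longer chain leaves the number level with the two shorter ethers, with a 1.4-fold higher number from compound 2 to compound 4 (0.13 log units; within the scatter) and a 1.2-fold higher number from compound 3 to compound 4 (0.09 log units; within the scatter). Butyl in place of hydrogen on the oxygen gives a 1.5-fold lower number from compound 1 to compound 4 (0.17 log units; within the scatter), so at this position only methoxymethyl, with a 2.0-fold lower number from compound 1 to compound 2 (0.31 log units; beyond the scatter), clears the scatter against compound 1. Nothing available explains why these chains read alike. Open, as far as these compounds go, is whether a chain longer than butyl, an amine or a carboxylic acid on an oxygen on an aromatic ring would move the number beyond the scatter.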